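The compounds below may be only part of what the source reports. "The series", "measured", "known", "first", "only" and "open" are said of these compounds alone.

Compound 1 `CC(C)(C)OC(=O)N1CCC2(CC1)CC(CCCOc1ccc(S(C)(=O)=O)cc1)C2` — 14 nM in a functional assay on cells for agonist activity at Glucose-dependent insulinotropic receptor (Homo sapiens), read by HTRF and cAMP accumulation, with a stated time of 30 min; a lower number here means that less compound is needed, a higher number that more compound is needed for the effect
Compound 2 `CC(C)(C)OC(=O)N1CCC2(CC1)CC(CCCOc1ccc(S(C)(=O)=O)c(F)c1)C2` — 9 nM
Compound 3 `CC1(OC(=O)N2CCC3(CC2)CC(CCCOc2ccc(S(C)(=O)=O)c(F)c2)C3)CC1` — 13 nM

The three measured compounds share one core and differ only at the aromatic ring and at the group on the oxygen next to the carbonyl. Their numbers lie close together: a 1.6-fold lower number from compound 1 to compound 2 (0.19 log units; within the scatter) and a 1.4-fold higher number from compound 2 to compound 3 (0.16 log units; within the scatter), so compound 3 cannot be separated from either of its neighbours, and compound 1 is its closest match.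

Compound 4 `CC(C)(C)COC(=O)N1CCC2(CC1)CC(CCCOc1ccc(S(C)(=O)=O)c(F)c1)C2` extends this row with one change, (neopentyl in place of 1-methylcyclopropyl on an oxygen next to a carbonyl group). Within the data shown here, of the two measured steps, only the one from compound 2 to compound 3 concerns the same place, the oxygen next to the carbonyl, and it was small. The step from compound 1 to compound 2 changes the aromatic ring and does not bear on this question. Among the measured compounds shown here, with only one relevant step, and that one within the scatter, the expectation is that the swap to neopentyl also leaves the number where it is; a step of a 1.2-fold higher number from compound 3 to compound 4 (0.06 log units; within the scatter) is estimated. Compound 4 is therefore expected to give about 15 nM, with a range from 7 nM to 35 nM.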

Compound 4, half-maximal effective concentration: 31 nM
The estimate for compound 4 lay 2.1-fold (0.32 log units) below the measured number; the range from low to high includes it.
By their numbers in this assay, from the lowest: compounds 2, 3 and 1 (each within the scatter of the next); then compound 4.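

In this assay the group on the oxygen next to a carbonyl group proves not to be freely exchangeable: 1-methylcyclopropyl in place of tert-butyl had stayed within the scatter, but neopentyl in place of 1-methylcyclopropyl gives a 2.4-fold higher number from compound 3 to compound 4 (0.38 log units; beyond the scatter) and neopentyl in place of tert-butyl gives a 3.4-fold higher number from compound 2 to compound 4 (0.54 log units; beyond the scatter) in the same series. Both steps are modest, yet they are the first at this position to lie beyond the scatter, so the position does respond to the group it carries, and of the three groups shown only neopentyl stands apart from the other two. Nothing shown here accounts for this difference.

The compounds shown leave open how a cyclobutyl group, an unbranched butyl chain or a chain ending in an amine would behave on this oxygen. They also leave open whether neopentyl would give a step of similar size on the aromatic ring without the fluoro, the ring carried by compound 1.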